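Sulfonamide shortening in a phospholipase series

The compounds below may be only part of what the source reports. "The series", "measured", "known", "first", "only" and "open" are said of these compounds alone.

Measured so far in an assay on COS-7 cells for inhibition of patatin-like phospholipase domain-containing protein 2 (Mus musculus), tested at 200 uM; a lower number here means less inhibition, a higher number more inhibition at the concentration tested (going by the name of the read-out):
- compound 1 `CCOC(=O)c1cccc(-c2ccc(CN(C)C)o2)c1`: 53%
- compound 2 `CCNS(=O)(=O)c1cccc(-c2ccc(OCC)cc2)c1`: 46%

Two compounds have numbers in this assay . Compound 2 stands lowest of the two; its nearest neighbour is compound 1, whose inhibition is higher by an amount that falls within the scatter of repeated measurements, so no order between compound 1 and compound 2 can be read from these two numbers. For the measured compounds named here, the two structures differ in several places at once, and no single-change step between them is known, so they say only what their two values show.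

Compound 3 `CCOc1ccc(-c2cccc(S(=O)(=O)NC)c2)cc1` is the next compound to be measured in this assay . It differs from compound 2 in one place: hydrogen in place of methyl on a saturated chain carbon bound to a sulfonamide nitrogen. This is the smallest kind of change in the series, the loss of one heavy atom on the ethylsulfamoyl group, giving methylsulfamoyl.

Going by the values given here, no step between measured compounds in this assay is available to calibrate a change of this kind. The expectation is therefore a step of a number 1 percentage points lower from compound 2 to compound 3 (within the scatter), that is, no change beyond the scatter in either direction. Compound 3 is estimated at 45%, with a range from 25% to 65%.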

Compound 3, a percentage reported as inhibition, at one concentration (the size of the read-out at that concentration, not a potency): 47%
For compound 3 the middle estimate is 2 percentage points below the measured one; the range from low to high includes it.
By their numbers in this assay, from the lowest: compounds 2, 3 and 1 (each within the scatter of the next).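

In this assay, the series now has its first step between compounds that differ in one place, and it reads a number 1 percentage points higher from compound 2 to compound 3 (within the scatter). The change from ethylsulfamoyl to methylsulfamoyl therefore leaves no difference that can be read at the single concentration tested, which the earlier pair, differing in several places at once, could not show for any one position. Within this pair, the methyl on a saturated chain carbon bound to a sulfonamide nitrogen can be replaced by hydrogen without a step beyond the scatter, and no measurement offered here bears on the reason for this.

Still open, on these data alone, is whether a longer chain such as propyl or butyl on the sulfonamide nitrogen, or the unsubstituted sulfonamide with only hydrogen on that nitrogen, would give a step beyond the scatter. Also open, as far as these compounds go, is what a carboxylic acid or an amine would do in place of the whole sulfamoyl group, and this single pair, read at one concentration, says nothing about potency.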